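This account rests on a few compounds, and the source may have more. Where it says the series, first, only, none or still open, it means among the compounds named here.

Compound 1, `N#CC1=C(N)Oc2c(c3nc4ccccc4nc3c3ccccc23)C12C(=O)N(Cc1cnnn1-c1ccccc1Cl)c1ccccc12`: 42600 nM
Compound 2, `N#CC1=C(N)Oc2c(c3nc4ccccc4nc3c3ccccc23)C12C(=O)N(Cc1cnnn1-c1cc(Cl)ccc1Cl)c1ccccc12`: a limit, > 50000 nM
Compound 3, `N#CC1=C(N)Oc2c(N)cc3nc4ccccc4nc3c2C12C(=O)N(Cc1cnnn1-c1ccccc1Cl)c1ccccc12`: 29800 nM

In a functional assay on A549 cells (Homo sapiens) for antiproliferative activity, read by MTT assay, with a stated time of 48 h (a higher number here means a weaker inhibitor, a lower number a stronger inhibitor), compound 1 gives 42600 nM. For compound 2 the result is only a limit of the assay, > 50000 nM. Compound 3 gives 29800 nM; its gap to compound 1 lies within the scatter. The result for compound 2 is a limit of the assay. So compound 3 cannot be set apart from the others. Compound 4, `N#CC1=C(N)Oc2c(N)cc3nc4ccccc4nc3c2C12C(=O)N(Cc1cnnn1-c1ccc([N+](=O)[O-])cc1)c1ccccc12`, differs from compound 3 by 4-nitrophenyl in place of 2-chlorophenyl on an aromatic nitrogen. Within the data shown here, the only measured step, an at least 1.1-fold higher number from compound 1 to compound 2 (0.06 log units; that floor lies within the scatter), concerns a chloro added on an aromatic carbon and lies within the scatter; no measured pair exchanges the aryl group on the five-membered ring. The expected step is therefore a 1.0-fold higher number from compound 3 to compound 4 (0.00 log units; within the scatter), nothing beyond the scatter. Compound 4 is estimated at 30000 nM, between 12000 nM and 75000 nM.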

Compound 4, half-maximal inhibitory concentration: > 50000 nM
Compound 4: a limit, no number; the forecaster's own chance of this, stated with the estimate: 30%; at least 1.6-fold (0.22 log units) between middle value and limit.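

In this assay, compound 4 gives > 50000 nM, a limit of the assay and not a number. This is the only exchange of the aryl group on the aromatic nitrogen shown here, and it reads an at least 1.6-fold higher number from compound 3 to compound 4 (0.22 log units; that floor lies within the scatter), so no change beyond the scatter is established. The full size of the step stays unknown because the reading ends at a limit: the limit of > 50000 nM in this assay, at which 2 of the 4 values shown sit.

The compounds shown leave open how far this position tolerates other groups. Whether an unsubstituted phenyl, or a phenyl carrying an amine or a carboxylic acid, would give a number remains unanswered.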